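From Methyl to Isopropyl on the Aromatic Nitrogen

The compounds below may be only part of what the source reports. "The series", "measured", "known", "first", "only" and "open" are said of these compounds alone.

Measured so far:
compound 1, `Cn1c(/C=C2\SC(=O)N(CC(=O)Nc3cc(C(C)(C)C)on3)C2=O)nc2ccccc21`: 31400 nM
compound 2, `CCn1c(/C=C2\SC(=O)N(CC(=O)N3CCOCC3)C2=O)nc2ccccc21`: > 50000 nM
compound 3, `Cn1c(/C=C2\SC(=O)N(CC(=O)N3CCCCC3)C2=O)nc2ccccc21`: > 50000 nM

The three measured compounds share one core and differ in the amide portion and in the group on the aromatic nitrogen. In a functional assay on DU-145 cells (Homo sapiens) for inhibition, read by MTT assay, with a stated time of 48 h (a higher number here means a weaker inhibitor, a lower number a stronger inhibitor), compound 1 gives 31400 nM. For compound 2 the result is only a limit of the assay, > 50000 nM. For compound 3 the result is likewise only a limit, > 50000 nM. For the measured compounds named here, compound 1 is therefore the one compound with a number rather than a limit; the other two sit at the limit of > 50000 nM in this assay, at which 2 of the 3 values shown sit. Going by the values given here, the single step between compounds that differ in one place, an at least 1.5-fold higher number from compound 1 to compound 3 (0.20 log units; that floor lies within the scatter), concerns the amide and not the aromatic nitrogen.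

Compound 4, `CC(C)n1c(/C=C2\SC(=O)N(CC(=O)Nc3cc(C(C)(C)C)on3)C2=O)nc2ccccc21`, is compound 1 with isopropyl in place of methyl on an aromatic nitrogen. Among the compounds with values here, no measured step changes this group alone; compound 2 carries an ethyl on the aromatic nitrogen but also a different amide, so it offers no clean comparison. Within the data shown here, with no step bearing on the change, the expectation is that a 1.1-fold higher number from compound 1 to compound 4 (0.05 log units; within the scatter) stays within the scatter. Compound 4 is thus estimated at 35000 nM, with a range from 12000 nM to 100000 nM, and a real chance that the assay reports only a limit.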

Compound 4, half-maximal inhibitory concentration: > 50000 nM
Compound 4: a limit, no number (the forecaster's own chance of this, stated with the estimate: 40%); middle value at least 1.4-fold (0.15 log units) from the limit.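

For the compounds shown here, this is the first step that changes only the group on the aromatic nitrogen, with isopropyl in place of methyl and the rest of compound 1 left as it stands: an at least 1.5-fold higher number from compound 1 to compound 4 (0.20 log units; that floor lies within the scatter). The reading for compound 4 in this assay is a limit of the assay and not a number, so the step gives only a floor, and that floor does not show a real change at this position; the true size of the step cannot be read. What the step does show is that keeping the amide of compound 1 is not enough to keep a number once isopropyl sits on this nitrogen, and the set now offers very little that can be compared directly: the limit of > 50000 nM in this assay, at which 3 of the 4 values shown sit.

As far as these compounds go, it remains open how far beyond the limit compound 4 lies, and whether any other group on this nitrogen, such as a plain hydrogen, a benzyl group or a longer chain like n-butyl, would give a lower number than compound 1. From the compounds shown here alone, the amide side is equally open, for instance whether a carboxylic acid or an amine on that part would change the picture.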